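The source may report more compounds than this note shows. Statements on the series, on what has been measured and on what is new or still open speak of the compounds shown alone.

Compound 1 `COc1ccc(/C=C/C(=O)c2ccccc2-c2ccc(F)cc2)cc1`: 670 nM
Compound 2 `COc1ccc(/C=C/C(=O)c2ccccc2-c2ccc(F)cc2)cc1B(O)O`: 220 nM
Compound 3 `COc1ccc(/C=C/C(=O)c2ccccc2-c2ccc(F)nc2)cc1`: not yet measured

Within the data shown here, in a functional assay on MCF7 cells (Homo sapiens) for antiproliferative activity, read by sulforhodamine B assay, with a stated time of 48 h (on this read-out lower numbers stand for stronger inhibition and higher numbers for weaker inhibition), compound 1 gives 670 nM, the higher of the two numbers so far. The change under review is 6-fluoropyridin-3-yl in place of 4-fluorophenyl on an aromatic carbon, on an aromatic carbon of a six-membered aromatic ring of carbon only, ortho to a large group. Among the measured compounds shown here, only one measured step is available: a 3.0-fold lower number from compound 1 to compound 2 (0.48 log units; beyond the scatter). That step replaces a hydrogen atom on an aromatic carbon and leaves the 4-fluorophenyl in place, so it offers no direct guide to this exchange. For the measured compounds named here, no measured compound carries a 6-fluoropyridin-3-yl, so the size of the step remains poorly constrained and the range must stay wide. The expected change is a 1.2-fold higher number from compound 1 to compound 3 (0.08 log units; within the scatter), which is not expected to go beyond the scatter. For compound 3 the estimated value is 800 nM, with an expected range of 250 nM to 2500 nM.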

Compound 3, half-maximal inhibitory concentration: 2700 nM
Estimate against measurement, compound 3: 3.4-fold (0.53 log units) below; measured number outside the range, above it.
By their numbers in this assay, from the lowest: compound 2; then compound 1; then compound 3.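

In this assay, exchanging 4-fluorophenyl for 6-fluoropyridin-3-yl is not a neutral swap: the step is a 4.0-fold higher number from compound 1 to compound 3 (0.61 log units; beyond the scatter). Among these compounds, the earlier step left the 4-fluorophenyl in place, so this is the first reading of this position, on an aromatic carbon of a six-membered aromatic ring of carbon only, ortho to a large group. It shows that the two rings are not interchangeable there, and that the entry of a ring nitrogen, with one hydrogen-bond acceptor, goes with weaker inhibition in this single pair. No measurement available here bears on the cause of this step.

Going by these compounds, whether the fluorine of the new ring contributes stays open, as a pyridin-3-yl without fluorine or a 4-chlorophenyl would test. Also open, on these data alone, is whether the step would hold with the boron-bearing group of compound 2 present.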